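This account rests on a few compounds, and the source may have more. Where it says the series, first, only, none or still open, it means among the compounds named here.

Measured so far:
Compound 1 `Cc1ccc(C(N)=O)cc1-n1c(C)cc(OCc2ccc(F)cc2F)c(Br)c1=O` gives 84%
Compound 2 `Cc1ccc(C(=O)N(C)C)cc1-n1c(C)cc(OCc2ccc(F)cc2F)c(Br)c1=O` gives 75%

Within the data shown here, in an ADME assay on microsomes from liver (Homo sapiens) for metabolic stability, read by LC-MS, using NADPH, with a stated time of 45 min, tested at 2 uM (a lower number here means that less of the compound is left, a higher number that more of the compound is left), compound 1 stands at 84% and its only neighbour, compound 2, stands at 75% so the two lie within the scatter of each other. Compound 3 `Cc1cc(OCc2ccc(F)cc2F)c(Br)c(=O)n1-c1cccc(C(N)=O)c1` departs from compound 1 by hydrogen in place of methyl on an aromatic carbon with hydrogen in place of methyl on an aromatic carbon. Among the measured compounds shown here, only one measured step exists, a number 9 percentage points lower from compound 1 to compound 2 (within the scatter) and it swaps dimethylamino in place of amino on a carbonyl carbon, which is a different place. For the measured compounds named here, no measured step covers the loss of this methyl, so the data give no ground for expecting a shift beyond the scatter. The expected step is a number 6 percentage points lower from compound 1 to compound 3 (within the scatter) as an estimate with little support. For compound 3 the estimated value is 78% with an expected range from 60% to 90% in this assay once it is measured.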

Compound 3, percent of the compound remaining: 100%
The estimate for compound 3 lay 22 percentage points below the measured number; the measured number lies above the stated range.
By their numbers in this assay, from the lowest: compounds 2 and 1 (each within the scatter of the next); then compound 3.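

Hydrogen in place of methyl on an aromatic carbon, ortho to a large group and para to a carbamoyl group, gives a number 16 percentage points higher from compound 1 to compound 3 (beyond the scatter) in this assay and is thereby the only single change shown that moves the number beyond the scatter. Among these compounds, the earlier step, dimethylamino in place of amino on a carbonyl carbon, stayed within the scatter, so this aromatic position is the first place where one change is clearly read. Nothing in the data speaks to why the number rises at this position. 

As far as these compounds go, whether a chlorine or a methoxy group at this same carbon would read closer to methyl or to hydrogen remains open. Also open, from the compounds shown here alone, is whether dimethylamino in place of amino on the carbonyl carbon would give the same step on the core of compound 3.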